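Swapping a ring substituent on the sulfonamide of compound 3

The source may hold more compounds than are shown below. What is called first, only, known or untested is meant among the compounds shown, and "the series" means these compounds.

Measured compounds:
compound 1, `CCOCCN(C[C@@H](O)CN1CCC2(CCN(c3ncnc4[nH]nc(C)c34)C2)C1)S(=O)(=O)c1c(C)cccc1C`, 17 nM in an assay on isolated protein for inhibition of RAC-alpha serine/threonine-protein kinase (Homo sapiens); a higher number here means a weaker inhibitor, a lower number a stronger inhibitor
compound 2, `Cc1cccc(C)c1S(=O)(=O)N1CCC[C@H]1[C@H](O)CN1CCC[C@@]2(CCN(c3ncnc(N)c3C3CC3)C2)C1`, 250 nM in this assay
compound 3, `Cc1cccc(C)c1S(=O)(=O)NC[C@@H](O)CN1CCC[C@@]2(CCN(c3ncnc(N)c3C3CC3)C2)C1`, 4 nM in this assay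

Of these three, compound 3 gives the lowest number in this assay, and so is the strongest inhibitor of the set: the gap to compound 1 is beyond the usual scatter, and the gap to compound 2 is far beyond it. Compound 4, `Cc1cc(F)ccc1S(=O)(=O)NC[C@@H](O)CN1CCC[C@@]2(CCN(c3ncnc(N)c3C3CC3)C2)C1`, keeps the whole of compound 3 except for one part. The change is 4-fluoro-2-methylphenyl in place of 2,6-dimethylphenyl on a sulfonyl sulfur. Going by the values given here, nothing among the measured compounds shows what this kind of swap does, so the expectation rests on the size of the change alone: a modest step, most likely toward a slightly higher number, but quite possibly within the scatter. The expected step from compound 3 to compound 4 is a 2.0-fold higher number from compound 3 to compound 4 (0.30 log units; within the scatter). Compound 4 is therefore estimated at 8 nM in this assay, with a range from 2 nM to 30 nM.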

Compound 4, half-maximal inhibitory concentration: 8 nM
For compound 4 middle estimate and measured number coincide at the digits printed, within the range that was stated.
By their numbers in this assay, from the lowest: compounds 3 and 4 (each within the scatter of the next); then compound 1; then compound 2.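

Moving to 4-fluoro-2-methylphenyl in place of 2,6-dimethylphenyl on a sulfonyl sulfur gives a 2.0-fold higher number from compound 3 to compound 4 (0.30 log units; within the scatter) in this assay, the first step at this position, and it lies within the scatter. The two groups, each with 8 heavy atoms, therefore cannot be told apart here, and 2,6-dimethylphenyl is not required for compound 4 to read 8 nM in this assay. Nothing available explains why these two groups read alike.

On these data alone, it remains open how this position responds to a larger change, such as a pyridine ring, a plain methyl, or a phenyl ring carrying an amine or a carboxylic acid. Also open, as far as these compounds go, is whether the same swap would read alike on compound 1 or compound 2, which both carry 2,6-dimethylphenyl on the sulfonyl sulfur.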